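A few compounds are considered here, and "the series" means these few. Any claim that something is new, unique, unknown or untested is made for them only; others in the source may bear on it.

Compound 1 `O=C(N/N=C/c1ccc(O)cc1)c1ccc(O)cc1` carries a hydroxy group on each aromatic ring, and in a physicochemical assay, read by spectrophotometry, with a stated time of 60 min, tested at 300 uM (a higher number here means a stronger effect of the compound at the concentration tested, a lower number a weaker effect), compound 1 gives 54.4%. Compound 2 `CC(C)(C)c1ccc(C(=O)N/N=C/c2ccc(O)cc2)cc1` gives 28.9% in this assay. The step of a number 25.5 percentage points higher from compound 2 to compound 1 (beyond the scatter) corresponds to hydroxy in place of tert-butyl on an aromatic carbon. Compound 3 `CC(C)(C)c1ccc(C(=O)N/N=C/c2cc(O)cc(O)c2)cc1` gives 20.1% in this assay; how its core differs from that of compound 2 is not broken down here, and the two values lie within the scatter of each other.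

Compound 4 `O=C(N/N=C/c1cc(O)cc(O)c1)c1ccc(O)cc1` has not yet been measured. It differs from compound 3 by hydroxy in place of tert-butyl on an aromatic carbon, the same change that turns compound 2 into compound 1, so this change occurs twice among these compounds. Within the data shown here, the step from compound 3 to compound 4 is expected to be a number 24.9 percentage points higher from compound 3 to compound 4 (beyond the scatter), because a number 25.5 percentage points higher from compound 2 to compound 1 (beyond the scatter) is the only measured instance of this change. Compound 4 is therefore estimated at 45%, with a likely span from 30% to 60%.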

Compound 4, a percentage reported as inhibition, at one concentration (the size of the read-out at that concentration, not a potency): 26.5%
The estimate for compound 4 lay 18.5 percentage points above the measured number; the whole stated range lies above it.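

In this assay the swap of hydroxy in place of tert-butyl on an aromatic carbon gave a number 25.5 percentage points higher from compound 2 to compound 1 (beyond the scatter) on one core but a number 6.4 percentage points higher from compound 3 to compound 4 (within the scatter) on the other. The step seen on the first core therefore did not carry over to the core of compound 3 at a size beyond the scatter. With only two instances, this shows that the step cannot be assumed to transfer between these two cores, but not that the change never matters on the core of compound 3, and nothing available bears on why the two cores part.

The compounds shown leave open how the same swap behaves on any third core. They also leave open what an amine or a carboxylic acid in that same place would give in this assay on either core.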